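The source may report more compounds than this note shows. Statements on the series, on what has been measured and on what is new or still open speak of the compounds shown alone.

Working notes on the series.

Compound 1 `CC(=O)N1N=C(c2cccc3ccccc23)CC1c1ccccc1[N+](=O)[O-]` carries a 2-nitrophenyl group on a saturated ring carbon of its core; in a functional assay on PC-3 cells (Homo sapiens) for cytotoxicity, read by sulforhodamine B assay, with a stated time of 48 h (a lower number here means a stronger inhibitor, a higher number a weaker inhibitor), compound 1 gives 3540 nM. Compound 2 `CC(=O)N1N=C(c2cccc3ccccc23)CC1c1cccc(Cl)c1Cl` keeps that core and differs from compound 1 in one place, (2,3-dichlorophenyl in place of 2-nitrophenyl on a saturated ring carbon), and in this assay compound 2 gives 20100 nM; the change made a 5.7-fold higher number from compound 1 to compound 2 (0.75 log units; beyond the scatter).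

Compound 3 `O=CCN1N=C(c2ccc3ccccc3c2)CC1c1ccccc1[N+](=O)[O-]` has the same atoms as compound 1 joined differently; the difference between the two cores is not broken down here. In this assay compound 3 gives 3010 nM, and the values of compound 3 and compound 1 stand within the scatter of each other.

Compound 4 `O=CCN1N=C(c2ccc3ccccc3c2)CC1c1cccc(Cl)c1Cl` is not yet measured. It differs from compound 3 by 2,3-dichlorophenyl in place of 2-nitrophenyl on a saturated ring carbon. This is the same kind of change as that from compound 1 to compound 2, but the place differs: here the ring atom beside it bears a formylmethyl group rather than an acetyl group. The step expected for compound 4 is a 5.3-fold higher number from compound 3 to compound 4 (0.73 log units; beyond the scatter), which rests on a 5.7-fold higher number from compound 1 to compound 2 (0.75 log units; beyond the scatter) seen with the acetyl core. For compound 4 the estimate in this assay is 16000 nM, expected between 6000 nM and 45000 nM.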

Compound 4, half-maximal inhibitory concentration: 17900 nM
For compound 4 the middle estimate is 1.1-fold (0.05 log units) below the measured one; low and high end bracket the measured number.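

In this assay, 2,3-dichlorophenyl in place of 2-nitrophenyl on a saturated ring carbon gives a 5.9-fold higher number from compound 3 to compound 4 (0.77 log units; beyond the scatter) on the core of compound 3. Set beside the earlier step, the change carries from one core to the other with its size kept: the same change on two cores in this assay, a 5.7-fold higher number (0.75 log units; beyond the scatter) from compound 1 to compound 2 and a 5.9-fold higher number (0.77 log units; beyond the scatter) from compound 3 to compound 4, 1.0-fold (0.02 log units) apart, within the scatter of two such steps

This agreement rests on a single pair on each core, in one cell line and one read-out, so it does not show that the step would keep its size on any further core. Nor does it show which part of the difference between the two cores, if any, bears on the step.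

The compounds shown leave open how a phenyl ring carrying an amine or a carboxylic acid would behave on this saturated ring carbon, since only two groups appear there. Also open, going by these compounds, is whether the step would survive a longer chain on the ring nitrogen in place of the formylmethyl or acetyl group.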